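Aryl Swap on the Amine of Compound 3

A few compounds are considered here, and "the series" means these few. Any claim that something is new, unique, unknown or untested is made for them only; others in the source may bear on it.

Compound 1 `FC(F)(F)c1ccc(CSc2nc(N3CCCCC3)c3ccccc3n2)cc1` gives 28400 nM in a functional assay on MDA-MB-231 cells (Homo sapiens) for cytotoxicity, read by MTT assay, with a stated time of 72 h; on this read-out higher numbers stand for weaker inhibition and lower numbers for stronger inhibition.
Compound 2 `FC(F)(F)c1ccc(CSc2nc(Nc3ccccc3)c3ccccc3n2)cc1` gives 18400 nM in this assay.
Compound 3 `FC(F)(F)c1ccc(CSc2nc(Nc3ccccc3Cl)c3ccccc3n2)cc1` gives > 50000 nM in this assay, which is a limit of the assay, not a number.

Compound 3 therefore sits at the limit of > 50000 nM in this assay, at which 1 of the 3 values shown sits, and its step of an at least 2.7-fold higher number from compound 2 to compound 3 (0.43 log units; beyond the scatter) shows only a floor, as does an at least 1.7-fold higher number from compound 1 to compound 3 (0.24 log units; that floor lies within the scatter). Compound 4 `FC(F)(F)c1ccc(CSc2nc(Nc3ccc(C(F)(F)F)cc3)c3ccccc3n2)cc1` differs by 4-(trifluoromethyl)phenyl in place of 2-chlorophenyl on a nitrogen on an aromatic ring. Among the measured compounds shown here, no measured step touches this change, so the direction in this assay is uncertain, and the step of an at least 1.2-fold lower number from compound 3 to compound 4 (0.09 log units; that floor lies within the scatter) is expected to be modest at most. Compound 4 is expected to give about 40000 nM, between 15000 nM and 100000 nM.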

Compound 4, half-maximal inhibitory concentration: 5460 nM
Compound 4: the middle estimate sits 7.3-fold (0.86 log units) above what was measured, outside the stated range (below it).
By their numbers in this assay, from the lowest: compound 4; then compounds 2 and 1 (each within the scatter of the next). At a limit, above all of these: compound 3.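

Exchanging the aryl group on this nitrogen can shift the number strongly in this assay, with an at least 9.1-fold lower number from compound 3 to compound 4 (0.96 log units; beyond the scatter), and that size is only a floor: the limit of > 50000 nM in this assay, at which 1 of the 4 values shown sits. A substituent on the anilino group does not only weaken inhibition, since trifluoromethyl in place of hydrogen gives a 3.4-fold lower number from compound 2 to compound 4 (0.53 log units; beyond the scatter). An aryl amine now also stands clearly apart from piperidin-1-yl, with a 5.2-fold lower number from compound 1 to compound 4 (0.72 log units; beyond the scatter), which plain anilino did not show.

Because 2-chlorophenyl and 4-(trifluoromethyl)phenyl differ in both group and numbered position, the compounds shown do not separate these two factors. As far as these compounds go, how a methoxy or a nitrile on this phenyl would read remains open.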